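From Methyl to Methylsulfanyl at One Aromatic Carbon

A few compounds are considered here, and "the series" means these few. Any claim that something is new, unique, unknown or untested is made for them only; others in the source may bear on it.

Of the compounds shown here, three on a shared core have been measured in an ADME assay on MRC5 cells (Homo sapiens), read by MTT assay, with a stated time of 72 h; on this read-out higher numbers stand for weaker inhibition and lower numbers for stronger inhibition. Compound 1 `COc1ncnc2c1c(-c1ccoc1)cn2[C@@H]1O[C@H](CO)[C@@H](O)[C@H]1O` gives 29400 nM. Compound 2 `CN(C)c1ncnc2c1c(-c1ccoc1)cn2[C@@H]1O[C@H](CO)[C@@H](O)[C@H]1O` reaches only a limit of the assay, > 100000 nM. Compound 3 `Cc1ncnc2c1c(-c1ccoc1)cn2[C@@H]1O[C@H](CO)[C@@H](O)[C@H]1O` gives 98300 nM, the highest of the two plain numbers, with compound 1 as its nearest neighbour. The step of a 3.3-fold higher number from compound 1 to compound 3 (0.52 log units; beyond the scatter) and the step of an at least 3.4-fold higher number from compound 1 to compound 2 (0.53 log units; beyond the scatter) both leave methoxy behind, while the comparison an at least 1.0-fold lower number from compound 2 to compound 3 (0.00 log units; that floor lies within the scatter) rests on the limit of > 100000 nM in this assay, at which 1 of the 3 values shown sits, and tells nothing further.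

Compound 4 `CSc1ncnc2c1c(-c1ccoc1)cn2[C@@H]1O[C@H](CO)[C@@H](O)[C@H]1O` has not been measured. It differs from compound 3 by methylsulfanyl in place of methyl on an aromatic carbon. For the measured compounds named here, no measured step introduces methylsulfanyl at that carbon, so the measured steps bear only indirectly: the methoxy of compound 1 gave the lowest number, and the methyl of compound 3 and the dimethylamino of compound 2 gave higher ones. Methylsulfanyl, like methoxy, carries one hydrogen-bond acceptor and a methyl on a single linking heavy atom, so the observer expects in this assay a step of a 1.8-fold lower number from compound 3 to compound 4 (0.25 log units; within the scatter) toward a lower number, small and possibly within the scatter. For compound 4 the observer estimates 55000 nM, within a range from 20000 nM to 150000 nM.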

Compound 4, half-maximal inhibitory concentration: > 100000 nM
Compound 4 gave a limit, no number; the forecaster's own chance of this, stated with the estimate: 30%; at least 1.8-fold (0.25 log units) between middle value and limit.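

In this assay compound 4 gives a limit of the assay and not a number, which places methylsulfanyl at the same limit as the dimethylamino of compound 2: the limit of > 100000 nM in this assay, at which 2 of the 4 values shown sit.

Methylsulfanyl therefore does not follow methoxy at this aromatic carbon, despite the likeness of the two groups, with an at least 3.4-fold higher number from compound 1 to compound 4 (0.53 log units; beyond the scatter); compound 1 now stands apart from each of the three other compounds by a step beyond the scatter, and methoxy is the only group shown here that gives a clearly lower number. With an at least 1.0-fold higher number from compound 3 to compound 4 (0.00 log units; that floor lies within the scatter), methylsulfanyl and methyl remain unseparated, and the step between the two limits cannot be read.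

What the compounds shown leave open is whether the lower number belongs to methoxy alone or extends to other groups on this carbon, such as ethoxy with its longer chain, a primary amine or chlorine. They also leave open how far compound 2 and compound 4 lie beyond their limits, and so whether these two compounds differ at all from each other.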